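Swapping pyrrole for furan at the assay limit

A few compounds are considered here, and "the series" means these few. Any claim that something is new, unique, unknown or untested is made for them only; others in the source may bear on it.

Compound 1 `COc1ccc(/C=C/C=C/C(=O)c2ccccc2)cc1` gives > 100000 nM, a limit.
Compound 2 `COc1ccc(/C=C/C=C/C(=O)c2ccc[nH]2)cc1` gives > 100000 nM, a limit.

In an ADME assay on RAW264.7 cells (Mus musculus) for cytotoxicity, read by MTT assay (a lower number here means a stronger inhibitor, a higher number a weaker inhibitor), compound 2 stands at > 100000 nM, which is a limit and not a number. Both measured compounds sit there (the limit of > 100000 nM in this assay, at which 2 of the 2 values shown sit). Compound 3 `COc1ccc(/C=C/C=C/C(=O)c2ccco2)cc1` makes one change: furan-2-yl in place of 1H-pyrrol-2-yl on a carbonyl carbon. For the measured compounds named here, the only measured step, a step that the two limits leave unreadable from compound 1 to compound 2, has no readable size, so it gives weak guidance. No change beyond the scatter is expected in this assay, and compound 3 will probably stay at the limit. The expected step is a number no higher from compound 2 to compound 3 (the limit leaves the size open). Compound 3 is estimated at 100000 nM, with an expected range of 50000 nM to 200000 nM.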

Compound 3, half-maximal inhibitory concentration: 76600 nM
Compound 3: the middle estimate sits 1.3-fold (0.12 log units) above what was measured; the range from low to high includes it.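

In this assay, compound 3 is the first compound shown to give a measured number and not a limit, so this position on the carbonyl carbon can carry a ring that brings a readable value. Furan-2-yl in place of 1H-pyrrol-2-yl gives an at least 1.3-fold lower number from compound 2 to compound 3 (0.11 log units; that floor lies within the scatter), and furan-2-yl in place of phenyl gives an at least 1.3-fold lower number from compound 1 to compound 3 (0.11 log units; that floor lies within the scatter). Only a floor can be read for either step, and it does not establish a real change: the limit of > 100000 nM in this assay, at which 2 of the 3 values shown sit.

As far as these compounds go, whether an amine or a carboxylic acid on this ring would give a clearly lower number remains open.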